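Cyclobutylmethyl for Branched Alkyl: Tolerance on Liver Cells

This account rests on a few compounds, and the source may have more. Where it says the series, first, only, none or still open, it means among the compounds named here.

Measured compounds and their values in an ADME assay on Huh-7 cells (Homo sapiens) for cytotoxicity, with a stated time of 72 h; a lower number here means that less compound is tolerated, a higher number that more compound is tolerated:
Compound 1, `CC(C)CCn1nc(-c2cccs2)c(O)c(C2=NS(=O)(=O)c3cc(S(C)(=O)=O)ccc3N2)c1=O`: "not determined" (no result reported)
Compound 2, `CCC(C)(C)Cn1nc(-c2cccs2)c(O)c(C2=NS(=O)(=O)c3cc(NS(C)(=O)=O)ccc3N2)c1=O`: > 1000 nM

Compound 1 gives no number in this assay. For compound 2 this assay reports only a limit, > 1000 nM. Going by the values given here, that sets where compound 2 stands: the one value shown for it is the limit of > 1000 nM in this assay, at which 1 of the 2 values shown sits, so no single number is known for either measured compound, and no step between measured compounds exists.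

Compound 3, `CS(=O)(=O)Nc1ccc2c(c1)S(=O)(=O)N=C(c1c(O)c(-c3cccs3)nn(CCC3CCC3)c1=O)N2`, has not yet been measured. It differs from compound 2 in one place: cyclobutylmethyl in place of 1,1-dimethylpropyl on a saturated chain carbon bound to an aromatic nitrogen. Both the group that leaves and the group that enters are hydrocarbon pieces of the same size, without donors or acceptors, on a saturated chain carbon bound to an aromatic nitrogen.

Among the compounds with values here, with no measured step to lean on, the step from compound 2 to compound 3 in this assay is expected to be small, with no direction beyond the scatter, as a step that the limit leaves unreadable from compound 2 to compound 3. Compound 3 is therefore estimated at 1500 nM, within 700 nM to 4000 nM, most likely again as a limit.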

Compound 3, half-maximal cytotoxic concentration: > 1000 nM
Compound 3 ended at the assay's limit (the forecaster's own chance of this, stated with the estimate: 80%); the middle value does not contradict the limit.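

No step can be read from compound 2 to compound 3 in this assay because each result is a limit and not a number: the limit of > 1000 nM in this assay, at which 2 of the 3 values shown sit.

Going by these compounds, what stays open is the concentration at which compound 2 or compound 3 would harm these cells, and whether cyclobutylmethyl and 1,1-dimethylpropyl differ at all in this respect.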